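Furan-3-yl for thiophen-3-yl on the shared core

The compounds below may be only part of what the source reports. "The series", "measured", "known", "first", "only" and "open" are said of these compounds alone.

Compound 1 `CNc1ncnc2c1c(-c1ccsc1)cn2[C@@H]1O[C@H](CO)[C@@H](O)[C@H]1O` is the starting point. In a functional assay on HL-60 cells (Homo sapiens) for antiproliferative activity, read by XTT assay, with a stated time of 72 h (on this read-out lower numbers stand for stronger inhibition and higher numbers for weaker inhibition), compound 1 returns only a limit, > 20000 nM, and not a number. Compound 2 `O=c1[nH]cnc2c1c(-c1cc3ccccc3o1)cn2[C@@H]1O[C@H](CO)[C@@H](O)[C@H]1O` also sits at a limit in this assay, > 20000 nM. Within the data shown here, compound 3 `COc1ncnc2c1c(-c1ccco1)cn2[C@@H]1O[C@H](CO)[C@@H](O)[C@H]1O` gives 100 nM in this assay, the only numerical reading among the three. Compound 1 thus stands with compound 2 at the weak end of what has been measured, at the limit of > 20000 nM in this assay, at which 2 of the 3 values shown sit. Among the measured compounds shown here, no two measured compounds differ in only one place, so no measured step is available; compound 3 differs from compound 1 in two places, and its value shows only that a numerical reading is reachable.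

Compound 4 `CNc1ncnc2c1c(-c1ccoc1)cn2[C@@H]1O[C@H](CO)[C@@H](O)[C@H]1O` is the next compound. It differs from compound 1 as follows: furan-3-yl in place of thiophen-3-yl on an aromatic carbon. For the measured compounds named here, the change is confined to one ring, and no measured step informs its size. The expected step of a number no higher from compound 1 to compound 4 (the limit leaves the size open) is none beyond the scatter. Compound 4 is expected to remain near the limit, with a fair chance that this assay again reports no number. The estimate for compound 4 is 20000 nM, with a range from 3000 nM to 60000 nM.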

Compound 4, half-maximal inhibitory concentration: > 15000 nM
Compound 4 gave a limit, no number (the forecaster's own chance of this, stated with the estimate: 60%); the middle value lies beyond the limit too.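

Compound 1 and compound 4 both return limits and not numbers in this assay, so the change from thiophen-3-yl to furan-3-yl gives no readable step. The compounds shown leave open whether this ring exchange changes antiproliferative activity at all, and what numerical values compound 1 and compound 4 would have.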